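The source may hold more compounds than are shown below. What is called first, only, known or untested is meant among the compounds shown, and "the series" means these compounds.

The measured compounds:
compound 1, `CC(=O)Nc1ccc(S(=O)(=O)NNC(=O)c2cccnc2Nc2ccc(Cl)cc2)cc1`, > 100000 nM
compound 2, `O=C(NNS(=O)(=O)c1ccc(F)cc1)c1cccnc1Nc1ccc(Cl)cc1Cl`, > 100000 nM

Both results come from a functional assay on SR cells (Homo sapiens) for antiproliferative activity; on this read-out lower numbers stand for higher toxicity in this test and higher numbers for lower toxicity in this test. For compound 1 the figure is only a limit of this assay, not a number: compound 1 gives > 100000 nM. Compound 2 likewise shows only a limit, > 100000 nM. Compound 1 therefore stands at the limit of > 100000 nM in this assay, at which 2 of the 2 values shown sit, and nothing in these two results separates it from compound 2.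

Compound 3 is `O=C(NNS(=O)(=O)c1ccc(Cl)cc1Cl)c1cccnc1Nc1ccc(Cl)cc1`, not yet measured in this assay. It differs from compound 1 in one place: 2,4-dichlorophenyl in place of 4-acetamidophenyl on a sulfonyl sulfur. Among the compounds with values here, no step between two measured compounds is available here, so the effect of this exchange on the sulfonyl sulfur has not been observed directly; the only other substituent at that position, in compound 2, leaves the picture unchanged.

In this assay the expected step is a number no higher from compound 1 to compound 3 (the limit leaves the size open), that is, no movement beyond the scatter. Compound 3 is accordingly estimated at 100000 nM, within a range of 20000 nM to 300000 nM, with a good chance that this assay once more reports only a limit.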

Compound 3, concentration lethal to 50% of the cells: 97700 nM
Compound 3: middle estimate off by 1.0-fold (0.01 log units), on the high side; the range from low to high includes it.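

In this assay compound 3 gives 97700 nM, the only actual number among the compounds shown, so a compound with 2,4-dichlorophenyl on the sulfonyl sulfur can be read within the range of this test. Compound 1, which carries 4-acetamidophenyl in that place, shows only a limit, > 100000 nM. The exchange therefore amounts to an at least 1.0-fold lower number from compound 1 to compound 3 (0.01 log units; that floor lies within the scatter), and this figure is only a floor, so the data show no change beyond the scatter but do not fix the true size of the step.

From the compounds shown here alone, the true size of the step remains unknown, and the picture still rests largely on a limit of the test: the limit of > 100000 nM in this assay, at which 2 of the 3 values shown sit. It also remains open whether the number for compound 3 depends on the two chlorine atoms of the 2,4-dichlorophenyl group or simply on the absence of 4-acetamidophenyl, and a plain phenyl, a 4-chlorophenyl or a short alkyl chain such as n-butyl on the sulfonyl sulfur would be needed to separate those two readings.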